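Phenyl for pyridin-3-yl on the carbonyl carbon

The compounds below may be only part of what the source reports. "The series", "measured", "known", "first", "only" and "open" are said of these compounds alone.

Of the compounds shown here, two have numbers so far in a physicochemical assay for solubility, read by LC-MS, in phosphate buffer, with a stated time of 24 h, at pH 7.4; a lower number here means a less soluble compound, a higher number a more soluble compound. Compound 1 `CN(C)Cc1ccc(C(=O)Nc2cnc(NCc3c(F)ccc4c3CCO4)n3cnnc23)cc1` gives 520000 nM. Compound 2 `O=C(Nc1cnc(NCc2c(F)ccc3c2CCO3)n2cnnc12)c1cccnc1` gives 12000 nM, the lower of the two numbers.

The next comparison is compound 3 `O=C(Nc1cnc(NCc2c(F)ccc3c2CCO3)n2cnnc12)c1ccccc1`, which departs from compound 2 in one place: phenyl in place of pyridin-3-yl on a carbonyl carbon. In words, this is phenyl in place of pyridin-3-yl on a carbonyl carbon.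

Going by the values given here, only one measured step bears on this place: a 43-fold lower number from compound 1 to compound 2 (1.64 log units; beyond the scatter), with pyridin-3-yl in place of 4-((dimethylamino)methyl)phenyl on a carbonyl carbon. That step is large and shows that the number can move with a change at this carbonyl carbon. Among the compounds with values here, it is a different exchange, however, and no measured pair compares pyridin-3-yl with phenyl directly. A much smaller step than that one is therefore expected, towards a lower number, and it may lie close to the scatter. The expected move is a 3.0-fold lower number from compound 2 to compound 3 (0.48 log units; beyond the scatter). The estimated value for compound 3 is 4000 nM, with an expected range of 1200 nM to 12000 nM.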

Compound 3, solubility: 2000 nM
The estimate for compound 3 lay 2.0-fold (0.30 log units) above the measured number; low and high end bracket the measured number.
By their numbers in this assay, from the lowest: compound 3; then compound 2; then compound 1.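

In this assay, the direct exchange on the carbonyl carbon, phenyl in place of pyridin-3-yl, gives a 6.0-fold lower number from compound 2 to compound 3 (0.78 log units; beyond the scatter), so a change of one ring atom, with the heavy-atom count unchanged, moves the number beyond the scatter. The aromatic carbon that carries (dimethylamino)methyl in compound 1 can now be read on its own: hydrogen in place of that group gives a 260-fold lower number from compound 1 to compound 3 (2.41 log units; beyond the scatter), a larger step than a 43-fold lower number from compound 1 to compound 2 (1.64 log units; beyond the scatter), which also includes the exchange of the ring. Nothing available gives a measured reason for either step.

The compounds shown leave open whether another amine, such as a morpholine or a piperazine, or a carboxylic acid on that aromatic carbon would hold the number near that of compound 1, or whether the (dimethylamino)methyl group is particular in this respect. They also leave open whether the step from pyridin-3-yl to phenyl keeps its size when (dimethylamino)methyl is present on the ring, and whether a second ring nitrogen would move the number further.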